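Removing One Methoxy Group: What to Expect for Compound 4

This account rests on a few compounds, and the source may have more. Where it says the series, first, only, none or still open, it means among the compounds named here.

Compound 1 `COc1cc(/C(Cl)=C/C=C(\C#N)C(=O)c2c[nH]c3ccccc23)cc(OC)c1OC`: in a functional assay on MCF7 cells (Homo sapiens) for cytotoxicity, read by sulforhodamine B assay, with a stated time of 48 h (on this read-out higher numbers stand for lower toxicity in this test and lower numbers for higher toxicity in this test), only a limit, > 100000 nM
Compound 2 `COc1cc(/C(Cl)=C/C=C(\C#N)C(=O)c2c[nH]c3ccc(Br)cc23)cc(OC)c1OC`: only a limit, > 100000 nM
Compound 3 `N#C/C(=C\C=C(/Cl)c1ccc(Br)cc1)C(=O)c1c[nH]c2ccccc12`: only a limit, > 100000 nM

Compound 1 therefore stands at the limit of the measurement, and no order among the three can be read, since every value sits at the limit of > 100000 nM in this assay, at which 3 of the 3 values shown sit. Within the data shown here, the single one-place step, a step that the two limits leave unreadable from compound 1 to compound 2, is unreadable for the same reason. Compound 4 `COc1ccc(/C(Cl)=C/C=C(\C#N)C(=O)c2c[nH]c3ccccc23)cc1OC` differs from compound 1 by hydrogen in place of methoxy on an aromatic carbon. Among the measured compounds shown here, no measured step bears on this change, so there is no basis to expect a step in this assay in either direction beyond the scatter. Compound 4 is expected near 150000 nM, between 40000 nM and 600000 nM, most likely again reported only as a limit, which would mean an estimated step that the limit leaves unreadable from compound 1 to compound 4.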

Compound 4, concentration lethal to 50% of the cells: > 100000 nM
Compound 4: only a limit was reported; the forecaster's own chance of this, stated with the estimate: 75%; the middle value does not contradict the limit.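

No step can be read from compound 1 to compound 4, since both values are only limits, as are those of compound 2 and compound 3: the limit of > 100000 nM in this assay, at which 4 of the 4 values shown sit. The compounds shown leave open whether swapping methoxy for hydrogen changes this read-out at all, and how the four compounds rank.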